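Notes on the shared core: propyl to cyclopentylmethyl

The compounds below may be only part of what the source reports. "The series", "measured", "known", "first", "only" and "open" are said of these compounds alone.

Measured so far, in a functional assay on MCF7 cells (Homo sapiens) for antiproliferative activity, read by sulforhodamine B assay, with a stated time of 48 h; a higher number here means a weaker inhibitor, a lower number a stronger inhibitor:
compound 1 `CC(=O)Nc1ccc(S(=O)(=O)Oc2ccccc2I)cc1` gives 27000 nM
compound 2 `CCC(=O)Nc1ccc(S(=O)(=O)Oc2ccccc2I)cc1` gives 8100 nM
compound 3 `CCCNC(=O)Nc1ccc(S(=O)(=O)Oc2ccccc2I)cc1` gives 2900 nM

Compound 3 stands lowest of the three: a 2.8-fold lower number from compound 2 to compound 3 (0.45 log units; beyond the scatter) and a 9.3-fold lower number from compound 1 to compound 3 (0.97 log units; beyond the scatter), both beyond the scatter. Compound 4 `O=C(NCC1CCCC1)Nc1ccc(S(=O)(=O)Oc2ccccc2I)cc1` differs from compound 3 by cyclopentyl in place of ethyl on a saturated chain carbon bound to an amide-type nitrogen. Among the measured compounds shown here, no measured step touches this place. For the measured compounds named here, the only steps at hand, a 3.3-fold lower number from compound 1 to compound 2 (0.52 log units; beyond the scatter) and a 2.8-fold lower number from compound 2 to compound 3 (0.45 log units; beyond the scatter), both lowered the number as the group on the carbonyl carbon grew, and bear on the new change only loosely. A modest further lowering is therefore expected, a 1.9-fold lower number from compound 3 to compound 4 (0.29 log units; within the scatter), with wide uncertainty. For compound 4 the estimate in this assay is 1500 nM, expected to fall between 500 nM and 5000 nM.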

Compound 4, half-maximal inhibitory concentration: 6600 nM
For compound 4 the middle estimate is 4.4-fold (0.64 log units) below the measured one; the measured number lies above the stated range.
By their numbers in this assay, from the lowest: compound 3; then compounds 4 and 2 (each within the scatter of the next); then compound 1.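

In this assay, among the compounds shown here, this is the first change on a saturated chain carbon bound to an amide-type nitrogen, and cyclopentyl in place of ethyl reverses the earlier trend, with a 2.3-fold higher number from compound 3 to compound 4 (0.36 log units; beyond the scatter). Part of the earlier gain is lost, since a 1.2-fold lower number from compound 2 to compound 4 (0.09 log units; within the scatter) is within the scatter, although a 4.1-fold lower number from compound 1 to compound 4 (0.61 log units; beyond the scatter) remains beyond it. No available evidence bears on the cause of this rise. As far as these compounds go, it remains open whether the ring itself or the carbon count accounts for the rise. A straight pentyl chain or a smaller cyclopropyl ring at this place would help separate the two.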